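This account rests on a few compounds, and the source may have more. Where it says the series, first, only, none or still open, it means among the compounds named here.

Measured so far:
- compound 1 `Cc1ccc(S(=O)(=O)Nc2ccc3c(c2)C(=O)N(Cc2ccc(Cl)cc2)C3=O)cc1`: 188000 nM
- compound 2 `Cc1ccc(S(=O)(=O)Nc2ccc3c(c2)C(=O)N(CCCCBr)C3=O)cc1`: reported only as a limit, > 200000 nM
- compound 3 `Cc1ccc(S(=O)(=O)Nc2ccc3c(c2)C(=O)N(Cc2ccccc2F)C3=O)cc1`: 195000 nM

In an assay on isolated protein for inhibition of lysosomal alpha-glucosidase (Rattus norvegicus), read by colorimetric assay (on this read-out lower numbers stand for stronger inhibition and higher numbers for weaker inhibition), compound 3 gives 195000 nM, the highest of the two numbers available; the nearest is compound 1, with a 1.0-fold higher number from compound 1 to compound 3 (0.02 log units; within the scatter). For compound 2 this assay returns only a limit, (the limit of > 200000 nM in this assay, at which 1 of the 3 values shown sits), so the step of an at least 1.0-fold lower number from compound 2 to compound 3 (0.01 log units; that floor lies within the scatter) carries a floor rather than a size. Compound 4 `Cc1ccc(S(=O)(=O)Nc2ccc3c(c2)C(=O)N(CCNc2ccccc2)C3=O)cc1` is not yet measured. It differs from compound 3 by anilinomethyl in place of 2-fluorophenyl on a saturated chain carbon bound to an amide-type nitrogen in a ring.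

For the measured compounds named here, both measured steps that change the group on this chain carbon, a 1.0-fold higher number from compound 1 to compound 3 (0.02 log units; within the scatter) and an at least 1.0-fold lower number from compound 2 to compound 3 (0.01 log units; that floor lies within the scatter), stay within the scatter, so exchanging one group for another at this position has not moved the number so far. The anilinomethyl group brings a hydrogen-bond donor and acceptor that none of the measured groups carried, but the series gives no step that tests such a change, and no cause can be read from it. The expectation is therefore a step in this assay of no change at the digits printed from compound 3 to compound 4 (within the scatter), that is, none beyond the scatter. Compound 4 is estimated at 195000 nM, in the range 110000 nM to 320000 nM, with a fair chance that only a limit is returned.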

Compound 4, half-maximal inhibitory concentration: 99600 nM
Compound 4: middle estimate off by 2.0-fold (0.29 log units), on the high side; measured number below the stated range.
By their numbers in this assay, from the lowest: compounds 4, 1 and 3 (each within the scatter of the next). At a limit, above all of these: compound 2.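

In this assay, anilinomethyl in place of 2-fluorophenyl gives a 2.0-fold lower number from compound 3 to compound 4 (0.29 log units; within the scatter), and anilinomethyl in place of 4-chlorophenyl gives a 1.9-fold lower number from compound 1 to compound 4 (0.28 log units; within the scatter), so this position has now taken a group with a hydrogen-bond donor and acceptor, and a chain nitrogen, without a step beyond the scatter. Compound 2 is reported only as a limit: the limit of > 200000 nM in this assay, at which 1 of the 4 values shown sits. The step to the new compound, an at least 2.0-fold lower number from compound 2 to compound 4 (0.30 log units; that floor lies within the scatter), therefore carries a floor rather than a size, and it adds a third comparison that does not leave the scatter.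

The compounds shown do not separate the anilino nitrogen from the change of 2-fluorobenzyl to 2-anilinoethyl as a whole, and a 2-phenylethyl group on the same nitrogen of the shared core would be the direct comparison for that. Also open, as far as these compounds go, is whether any group at this position can produce a step beyond the scatter, for example a carboxylic acid or a primary amine at the end of the chain, or a longer chain carrying the anilino group.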